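Compound 4: (carboxymethyl)amino for nitro, expectation

The source may report more compounds than this note shows. Statements on the series, on what has been measured and on what is new or still open speak of the compounds shown alone.

Three compounds on the shared core have been run in an assay for inhibition of Tryptophan 2,3-dioxygenase (Homo sapiens), with stated times of 10 min and 60 min, tested at 100 uM; on this read-out higher numbers stand for a stronger effect at the one concentration tested and lower numbers for a weaker effect. Compound 1 `Nc1cccc(CNc2cc(C(F)(F)F)cc3[nH]ncc23)c1` gives 89%. Compound 2 `O=[N+]([O-])c1ccccc1CNc1cc(C(F)(F)F)cc2[nH]ncc12` gives 95%. Compound 3 `O=[N+]([O-])c1cccc(CNc2cc(C(F)(F)F)cc3[nH]ncc23)c1` gives 82%, the lowest of the three numbers; compound 1 sits nearest to it, with a gap that lies within the scatter, while compound 2 sits furthest, with a gap that lies beyond it.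

Within the data shown here, the single measured one-place step is a number 7 percentage points lower from compound 1 to compound 3 (within the scatter), a nitro in place of amino on an aromatic carbon.

Compound 4 `O=C(O)CNc1cccc(CNc2cc(C(F)(F)F)cc3[nH]ncc23)c1` is not yet measured. It differs from compound 3 in one place: (carboxymethyl)amino in place of nitro on an aromatic carbon. Among the measured compounds shown here, the only step that bears on this position is the one from compound 1 to compound 3, and it stayed within the scatter; no measured step replaces nitro with (carboxymethyl)amino, so the size of this particular exchange is unknown. Since the earlier exchange at the same position moved the read-out little, the step from compound 3 to compound 4 is expected to be small, a number 2 percentage points higher from compound 3 to compound 4 (within the scatter), in no clear direction beyond the scatter. On that basis compound 4 is estimated at 84% in this assay, with a range from 62% to 97%.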

Compound 4, a percentage reported as inhibition, at one concentration (the size of the read-out at that concentration, not a potency): 65%
Estimate against measurement, compound 4: 19 percentage points above; measured number inside the range.
By their numbers in this assay, from the lowest: compound 4; then compounds 3, 1 and 2 (each within the scatter of the next, the first and the last beyond it).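

In this assay, among these compounds, this place on the aromatic ring now shows a change beyond the scatter for the first time: (carboxymethyl)amino in place of nitro gives a number 17 percentage points lower from compound 3 to compound 4 (beyond the scatter) and so separates itself from the earlier amino and nitro pair, whose step stayed within the scatter. Carboxymethyl in place of hydrogen on the aromatic amino nitrogen gives a number 24 percentage points lower from compound 1 to compound 4 (beyond the scatter) and shows that the lower number holds against both smaller groups, so this position does not treat all substituents alike, although compound 4 at 65% keeps a clear effect at the one concentration tested. No measurement at hand accounts for this drop.

The compounds shown do not separate the contribution of the carboxylic acid from that of the added chain on the nitrogen, a question that a methyl ester, a primary amide or a simple ethyl group on that nitrogen would address. Also open, as far as these compounds go, is how a longer chain ending in a carboxylic acid would read in this assay and whether the same (carboxymethyl)amino group would give a similar step at the ring position held by nitro in compound 2.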